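This account rests on a few compounds, and the source may have more. Where it says the series, first, only, none or still open, it means among the compounds named here.

The three measured compounds, all sharing one core and differing only in the side chain on the amino-acid part:

compound 1, `N=C(N)NCCC[C@H](NC(=O)CN(c1nc(Cl)nc2[nH]cnc12)C1CC1)C(=O)O`, gives 7.19% in a functional assay on the whole organism (Tail, strain ICR) with Mus musculus as the target, in the tail flick test, with a stated time of 150 min, at a dose of 25 umol/kg by the oral route; a higher number here means a stronger effect of the compound at the dose given, a lower number a weaker effect
compound 2, `NC(=O)C[C@H](NC(=O)CN(c1nc(Cl)nc2[nH]cnc12)C1CC1)C(=O)O`, gives 7.51% in this assay
compound 3, `CC(C)[C@H](NC(=O)CN(c1nc(Cl)nc2[nH]cnc12)C1CC1)C(=O)O`, gives 7.86% in this assay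

Among the compounds with values here, compound 3 holds the highest of the three numbers, but its gaps to the others are small: a number 0.4 percentage points higher from compound 2 to compound 3 (within the scatter) and a number 0.7 percentage points higher from compound 1 to compound 3 (within the scatter), both within the scatter, so no compound can be called the more active one.

Compound 4, `CSCC[C@H](NC(=O)CN(c1nc(Cl)nc2[nH]cnc12)C1CC1)C(=O)O`, carries a further change at the same place: 2-(methylsulfanyl)ethyl in place of isopropyl on a saturated chain carbon bound to an amide-type nitrogen and a carbonyl carbon. Within the data shown here, the steps that bear on this are the two that exchanged groups on that same chain carbon, a number 0.7 percentage points higher from compound 1 to compound 3 (within the scatter) and a number 0.4 percentage points higher from compound 2 to compound 3 (within the scatter), and the related exchange a number 0.3 percentage points higher from compound 1 to compound 2 (within the scatter); every one of them stayed within the scatter, however different the groups were. The expected step for compound 4 is therefore a number 0.2 percentage points lower from compound 3 to compound 4 (within the scatter), that is, none beyond the scatter. Compound 4 is estimated to give 7.7% in this assay, with a range from 2.5% to 14%.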

Compound 4, a percentage reported as activity, at one dose (the size of the read-out at that dose, not a potency): 4.14%
Compound 4: the middle estimate sits 3.6 percentage points above what was measured; low and high end bracket the measured number.
By their numbers in this assay, from the lowest: compounds 4, 1, 2 and 3 (each within the scatter of the next).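

Placing 2-(methylsulfanyl)ethyl on this saturated chain carbon, the first side chain here to carry sulfur, still gives no readable difference in this assay: the exchange for isopropyl gives a number 3.7 percentage points lower from compound 3 to compound 4 (within the scatter), while the comparisons with the other two side chains give a number 3.4 percentage points lower from compound 2 to compound 4 (within the scatter) and a number 3.1 percentage points lower from compound 1 to compound 4 (within the scatter). These are the largest steps seen so far at this position, yet all of them stay inside the scatter, so compound 4 cannot be set apart from the other three. Nothing given here bears on the reason for these numbers.

Going by these compounds, it remains open whether a ring-bearing side chain such as benzyl, or a free carboxylic acid or amine on the chain, would move the number beyond the scatter. With one dose and one time, these readings also say nothing about potency.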